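The compounds below may be only part of what the source reports. "The series", "measured", "known", "first", "only" and "open" are said of these compounds alone.

Of the compounds shown here, three built on one shared core have been measured in an ADME assay on microsomes from liver (Homo sapiens) for metabolic stability, tested at 2.5 uM; on this read-out lower numbers stand for slow clearance and higher numbers for fast clearance. Compound 1 `O=S(=O)(c1ccc(F)c(Cl)c1)c1cnc2c(F)cccc2c1-c1cccc(F)c1` gives 1.23 mL/min, and compound 2 `O=S(=O)(c1ccc(F)c(F)c1)c1cnc2c(F)cccc2c1-c1ccccc1F` gives 1.39 mL/min. Compound 3 `N#Cc1cccc(S(=O)(=O)c2cnc3c(F)cccc3c2-c2cccc(F)c2)c1` gives 0.34 mL/min, the lowest of the three numbers; compound 1 is its nearest neighbour and compound 2 lies furthest from it. Between compound 1 and compound 3 there is a single change of one group, and the step reads a 3.6-fold lower number from compound 1 to compound 3 (0.56 log units; beyond the scatter).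

Compound 4 `O=S(=O)(c1ccc(F)c(F)c1)c1cnc2c(F)cccc2c1-c1cccc(F)c1` differs from compound 3 in one place: 3,4-difluorophenyl in place of 3-cyanophenyl on a sulfonyl sulfur. The group that leaves carries one hydrogen-bond acceptor, the group that enters carries none, so this change runs largely opposite to the step from compound 1 to compound 3, with 3,4-difluorophenyl rather than 3-chloro-4-fluorophenyl arriving. Compound 2 also carries 3,4-difluorophenyl on the sulfonyl sulfur, though with a different group elsewhere on the core, and its value sits close to that of compound 1. Going by the values given here, the one measured step that bears on this change therefore points to a rise of modest size, back toward the numbers seen for compound 1 and compound 2. The expected step is a 3.5-fold higher number from compound 3 to compound 4 (0.55 log units; beyond the scatter). The estimate for compound 4 is 1.2 mL/min, with a range from 0.7 mL/min to 2 mL/min.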

Compound 4, intrinsic clearance in a liver preparation (reported as CLH), per the amount of preparation that the assay uses: 1.28 mL/min
Estimate against measurement, compound 4: 1.1-fold (0.03 log units) below; measured number inside the range.
By their numbers in this assay, from the lowest: compound 3; then compounds 1, 4 and 2 (each within the scatter of the next).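

In this assay, the low number of compound 3 now stands against two different halogen-bearing groups on the sulfonyl sulfur, not one: putting 3,4-difluorophenyl in place of 3-cyanophenyl gives a 3.8-fold higher number from compound 3 to compound 4 (0.58 log units; beyond the scatter), a step of about the same size as the earlier 3.6-fold lower number from compound 1 to compound 3 (0.56 log units; beyond the scatter), though in the opposite direction. The two other comparisons show that, among these compounds, the halogen details matter far less than that swap: fluoro in place of chloro on an aromatic carbon gives a 1.0-fold higher number from compound 1 to compound 4 (0.02 log units; within the scatter), and 3-fluorophenyl in place of 2-fluorophenyl on an aromatic carbon gives a 1.1-fold lower number from compound 2 to compound 4 (0.04 log units; within the scatter), both within the scatter. Nothing measured here explains why the number changes with these groups.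

The compounds shown cannot tell whether the low number depends on the nitrile itself, since 3-cyanophenyl is the only group of its kind here and no phenyl group carrying a methoxy group or an amine can be compared with it. As far as these compounds go, it also stays open whether 3-cyanophenyl would give a similarly low number alongside 2-fluorophenyl on the shared core.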